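Carbamate in Place of Urea on the Shared Core

The source may report more compounds than this note shows. Statements on the series, on what has been measured and on what is new or still open speak of the compounds shown alone.

Compound 1 `O=C(NC1CCNCC1)N1CCC(c2nc(-c3ccc4ccccc4n3)no2)CC1` is the weakest of the three measured compounds in a functional assay on Shh Light II cells (Mus musculus) for inhibition, read by a luciferase reporter (a lower number here means a stronger inhibitor, a higher number a weaker inhibitor), giving 2500 nM. Compound 2 `O=C(NC1CC[S+]([O-])CC1)N1CCC(c2nc(-c3ccc4ccccc4n3)no2)CC1` gives 850 nM, and compound 3 `COc1ccccc1NC(=O)N1CCC(c2nc(-c3ccc4ccccc4n3)no2)CC1` gives 410 nM. Compound 4 `COc1ccccc1OC(=O)N1CCC(c2nc(-c3ccc4ccccc4n3)no2)CC1` differs from compound 1 by 2-methoxyphenoxy in place of (piperidin-4-yl)amino on a carbonyl carbon. Within the data shown here, the measured step that bears most on this is the one to compound 3, a 6.1-fold lower number from compound 1 to compound 3 (0.79 log units; beyond the scatter), which introduced the same methoxyphenyl ring; the change to compound 2, a 2.9-fold lower number from compound 1 to compound 2 (0.47 log units; beyond the scatter), also lowered the number. Among the measured compounds shown here, no measured pair tests the 2-methoxyphenoxy group itself, so that part of the change carries extra uncertainty. Compound 4 is therefore expected to show a 5.0-fold lower number from compound 1 to compound 4 (0.70 log units; beyond the scatter) in this assay. The estimated value of compound 4 is 500 nM, with a range from 150 nM to 1800 nM.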

Compound 4, half-maximal inhibitory concentration: 250 nM
For compound 4 the middle estimate is 2.0-fold (0.30 log units) above the measured one; low and high end bracket the measured number.
By their numbers in this assay, from the lowest: compounds 4 and 3 (each within the scatter of the next); then compound 2; then compound 1.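

Replacing (2-methoxyphenyl)amino with 2-methoxyphenoxy on the carbonyl carbon gives a 1.6-fold lower number from compound 3 to compound 4 (0.21 log units; within the scatter), so this assay does not separate the carbamate from the urea when the methoxyphenyl ring is kept. The carbamate also holds the advantage of that ring over the non-aromatic ring groups, with a 10-fold lower number from compound 1 to compound 4 (1.00 log units; beyond the scatter) and a 3.4-fold lower number from compound 2 to compound 4 (0.53 log units; beyond the scatter) at this position.

On these data alone, it remains open whether an unsubstituted phenoxy group or a benzyloxy group would perform similarly on this carbonyl carbon in this assay as well. No supporting data bear on what underlies these numbers.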